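This account rests on a few compounds, and the source may have more. Where it says the series, first, only, none or still open, it means among the compounds named here.

Working notes. The series shares one core, seen in compound 1 `Cc1ccc(-c2n[nH]cc2N2CCCNCC2)cc1`, compound 2 `Fc1ccc(-c2n[nH]cc2N2CCCNCC2)cc1` and compound 3 `COc1ccccc1-c1n[nH]cc1N1CCCNCC1`, each tested in an assay on isolated protein for binding affinity to 5-hydroxytryptamine receptor 4 (Homo sapiens); on this read-out lower numbers stand for stronger inhibition and higher numbers for weaker inhibition. For compound 1 only a limit is known, > 10000 nM. Compound 2 likewise gives only a limit, > 10000 nM. Compound 3 also sits at the limit, > 10000 nM, so its standing is the edge of the assay rather than a number. Across the three, the picture is the limit of > 10000 nM in this assay, at which 3 of the 3 values shown sit. Among the measured compounds shown here, the one measured step, a step that the two limits leave unreadable from compound 1 to compound 2, cannot be sized. Compound 4 `c1ccc(-c2n[nH]cc2N2CCCNCC2)cc1` differs from compound 3 by hydrogen in place of methoxy on an aromatic carbon. For the measured compounds named here, no measured step bears on this change, and none yielded a readable number. Compound 4 is therefore expected to remain at or near the limit, an estimated step that the limit leaves unreadable from compound 3 to compound 4. Compound 4 is estimated at 20000 nM, within 4000 nM to 100000 nM.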

Compound 4, inhibition constant: > 10000 nM
Compound 4: no number, only a limit; the forecaster's own chance of this, stated with the estimate: 80%; the middle value lies beyond the limit too.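

Among the compounds shown here, compound 4 gives only a limit, > 10000 nM, so no step from compound 1, compound 2 or compound 3 to compound 4 can be read. The compounds shown leave open whether any change on the shared core gives a readable value in this assay.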